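Moving One Chlorine in a Small Amide Series

A few compounds are considered here, and "the series" means these few. Any claim that something is new, unique, unknown or untested is made for them only; others in the source may bear on it.

In a functional assay on ACHN cells (Homo sapiens) for cytotoxicity, read by sulforhodamine B assay, with a stated time of 72 h (a higher number here means a weaker inhibitor of growth, a lower number a stronger inhibitor of growth), compound 1 (`O=C(Nc1ccccc1O)C1CCc2ccccc2N1C(=O)c1ccccc1Cl`) gives 44200 nM, compound 2 (`O=C(Nc1cc(C(F)(F)F)cc(C(F)(F)F)c1)C1CCc2ccccc2N1C(=O)c1ccc(Cl)cc1`) gives 2570 nM, and compound 3 (`O=C(Nc1ccccc1C(F)(F)F)C1CCc2ccccc2N1C(=O)c1ccc(Cl)cc1`) gives 824 nM. Compound 2 therefore holds the middle place, a weaker inhibitor of growth than compound 3 and a stronger one than compound 1, with both gaps beyond the scatter. Compound 4 (`O=C(Nc1cc(C(F)(F)F)cc(C(F)(F)F)c1)C1CCc2ccccc2N1C(=O)c1cccc(Cl)c1`) differs from compound 2 by 3-chlorophenyl in place of 4-chlorophenyl on a carbonyl carbon. Among the measured compounds shown here, no measured pair shows what such a change does, so the expectation starts from compound 2 at 2570 nM and foresees no step beyond the scatter in this assay. The estimated step is a 1.0-fold lower number from compound 2 to compound 4 (0.01 log units; within the scatter). For compound 4 the expected value is 2500 nM, within an estimated range of 900 nM to 7000 nM.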

Compound 4, concentration for 50% growth inhibition: 813 nM
Estimate against measurement, compound 4: 3.1-fold (0.49 log units) above, outside the stated range (below it).
By their numbers in this assay, from the lowest: compounds 4 and 3 (each within the scatter of the next); then compound 2; then compound 1.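

Moving the chlorine alone, with the same atoms kept, is enough to shift growth inhibition in this assay by a 3.2-fold lower number from compound 2 to compound 4 (0.50 log units; beyond the scatter), a step beyond the usual scatter. The earlier compounds shown here could not show this, and it means that the place of the chlorine on this phenyl ring matters when the rest of compound 2 is held fixed. Nothing measured here explains the shift.

As far as these compounds go, whether 3-chlorophenyl gives a similar step with the other amide group of compound 3 remains open. So does the effect of an amine or a carboxylic acid in place of the chlorine.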